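The source may hold more compounds than are shown below. What is called first, only, known or untested is meant among the compounds shown, and "the series" means these compounds.

Compound 1 `COc1cc(OC)c(OC)cc1/C=C/COC(=O)/C=C/c1ccc(OC)c(OC)c1`: 75%
Compound 2 `COc1cc(OC)c(OC)cc1/C=C/COC(=O)/C=C/c1ccccc1C(F)(F)F`: 75%
Compound 3 `COc1cc(OC)c(OC)cc1/C=C/COC(=O)/C=C/c1cc(OC)c(OC)c(OC)c1`: not yet measured

In a functional assay on the whole organism (strain Kunming) with Mus musculus as the target, with a stated time of 0.5 h, at a dose of 300 mg/kg by the intraperitoneal route (on this read-out lower numbers stand for a stronger effect and higher numbers for a weaker effect at the one dose given), compound 1 gives 75% and stands level with compound 2, the nearest measured compound, which gives 75%. Within the data shown here, the one measured step, no change at the digits printed from compound 1 to compound 2 (within the scatter), shows that swapping one aryl group for another left the read-out unchanged. Compound 3 differs from compound 1 by methoxy in place of hydrogen on an aromatic carbon. Among the measured compounds shown here, that step bears little resemblance to the measured one, so the only guide is that both measured compounds sit at the same level. The step of no change at the digits printed from compound 1 to compound 3 (within the scatter) is expected to stay within the scatter. For compound 3 the estimate is 75%, in the range 55% to 90%.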

Compound 3, a percentage reported as activity, at one dose (the size of the read-out at that dose, not a potency): 75%
Compound 3: the middle estimate sits on the measured number at the digits printed, and the stated range covers the measured number.
By their numbers in this assay, from the lowest: compounds 1, 2 and 3 (each within the scatter of the next).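

In this assay, methoxy in place of hydrogen on an aromatic carbon, ortho to a methoxy group, gives no change at the digits printed from compound 1 to compound 3 (within the scatter). Where the earlier step swapped one whole aryl group for another, this one isolates a single position and shows that the added methoxy leaves the read-out within the scatter at this one dose. Nothing available explains this result.

From the compounds shown here alone, whether an amine, a carboxylic acid or a longer alkoxy chain at this position would shift the read-out remains open. So does whether an amide in place of the ester would do so.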